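One methoxyphenyl swap, measured once, expected again

The compounds below may be only part of what the source reports. "The series", "measured", "known", "first", "only" and "open" are said of these compounds alone.

Compound 1, `COC(=O)c1cccc(OCc2oc(-c3ccccc3OC)nc2C)c1`, gives 7330 nM in an assay on cells for antagonist activity at vitamin D3 receptor (Homo sapiens), read by a luciferase reporter; a higher number here means a weaker inhibitor, a lower number a stronger inhibitor.
Compound 2, `COC(=O)c1cccc(OCc2oc(-c3cccc(OC)c3)nc2C)c1`, gives 17100 nM in this assay.
Compound 3, `COc1ccccc1-c1nc(C)c(COc2ccccc2C(=O)O)o1`, reaches only a limit of this assay, > 80000 nM.

All three compounds share a methyl ester or carboxylic acid on one aromatic ring, linked through an ether to a five-membered aromatic ring that carries a methoxyphenyl group. Compound 1 and compound 2 differ in one place only: 3-methoxyphenyl in place of 2-methoxyphenyl on an aromatic carbon. That swap gives a 2.3-fold higher number from compound 1 to compound 2 (0.37 log units; beyond the scatter), so in this assay the 3-methoxyphenyl analogue is the weaker inhibitor of the pair, by a margin that sits beyond the scatter but remains modest.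

Compound 3 carries a different core from compound 1; how the two cores differ is not broken down here. For compound 3 only a limit is known, (the limit of > 80000 nM in this assay, at which 1 of the 3 values shown sits), so no number is available as a starting point.

Compound 4, `COc1cccc(-c2nc(C)c(COc3ccccc3C(=O)O)o2)c1`, is not yet measured. It stands to compound 3 exactly as compound 2 stands to compound 1: 3-methoxyphenyl in place of 2-methoxyphenyl on an aromatic carbon, at the same place on the five-membered ring, so this is the same change. Given that the earlier swap gave a 2.3-fold higher number from compound 1 to compound 2 (0.37 log units; beyond the scatter), the expected step that the limit leaves unreadable from compound 3 to compound 4 is a further weakening of a similar modest size. Since compound 3 already sits at the limit, compound 4 is expected to give 150000 nM, most likely again reported only as a limit, within a range of 50000 nM to 500000 nM.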

Compound 4, half-maximal inhibitory concentration: > 33000 nM
Compound 4 gave a limit, no number; the forecaster's own chance of this, stated with the estimate: 85%; the middle value is on the limit's open side.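

In this assay, compound 3 and compound 4 each give only a limit and no number, so the step between them cannot be read. The compounds shown leave open whether 3-methoxyphenyl in place of 2-methoxyphenyl shifts the result on the core of compound 3 in the same direction as it does on the core of compound 1, and by how much.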